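Growing the alkyl group on the ring oxygen in compound 2

A few compounds are considered here, and "the series" means these few. Any claim that something is new, unique, unknown or untested is made for them only; others in the source may bear on it.

Of the compounds shown here, three share one core and have been tested in a functional assay on the whole organism (stomach) for inhibition, with Rattus norvegicus as the target, at a dose of 80 mg/kg; on this read-out higher numbers stand for more inhibition at the one dose given (going by the name of the read-out) and lower numbers for less inhibition. Compound 1 `CC(C)c1ccc(-c2oc3ccc(C(=O)O)cc3c(=O)c2O)cc1` gives 24%. Compound 2 `COc1c(-c2ccc(C(C)C)cc2)oc2ccc(C(=O)O)cc2c1=O` gives 18%, the lowest of the three numbers, though its gap to compound 1 lies within the scatter. Compound 3 `COc1c(-c2ccc(Cl)cc2)oc2ccc(C(=O)O)cc2c1=O` gives 34%, and this one does stand beyond the scatter above compound 2.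

The unmeasured compound 4 `CC(C)Oc1c(-c2ccc(C(C)C)cc2)oc2ccc(C(=O)O)cc2c1=O` differs from compound 2 in a single place: isopropyl in place of methyl on an oxygen on an aromatic ring. Among the compounds with values here, one measured step touches the same oxygen: a number 6 percentage points lower from compound 1 to compound 2 (within the scatter). Adding a methyl there changed little. The other step, a number 16 percentage points higher from compound 2 to compound 3 (beyond the scatter), concerns a different place, the aromatic carbon, and says nothing direct about alkyl groups on the oxygen. Within the data shown here, only one step speaks to the site in question, and it was within the scatter, so compound 4 is expected to show no step beyond the scatter in this assay, in either direction.

Compound 4 is therefore estimated at 18%, with a range from 6% to 32%. The step from compound 2 that this estimate means, no change at the digits printed from compound 2 to compound 4 (within the scatter), is expected to be small.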

Compound 4, a percentage reported as inhibition, in the whole organism at one dose (the size of the read-out at that dose, not a potency): 20%
Beside the measured number, compound 4's estimate is 2 percentage points below it; the measured number falls inside the stated range.
By their numbers in this assay, from the lowest: compounds 2, 4, 1 and 3 (each within the scatter of the next, the first and the last beyond it).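

Until now, this oxygen had only been seen carrying hydrogen or methyl, and in this assay the larger isopropyl also leaves the number close to that of the methyl analogue, with a number 2 percentage points higher from compound 2 to compound 4 (within the scatter) as the step. Comparing isopropyl directly with hydrogen on the same oxygen gives a number 4 percentage points lower from compound 1 to compound 4 (within the scatter), so with isopropyl on the aromatic ring, hydrogen, methyl and isopropyl on this oxygen all give numbers within the scatter of one another, and going from one to three carbons in this alkyl group produces no readable change at this one dose. No supporting measurement is available to explain this lack of response.

As far as these compounds go, it remains open whether a longer chain, or a chain ending in an amine or a carboxylic acid, on this oxygen would shift the number beyond the scatter. Within the data shown here, also unresolved is whether isopropyl on the oxygen would give the same result when chloro replaces isopropyl on the aromatic carbon, the one change here that has produced a step beyond the scatter.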